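The source may hold more compounds than are shown below. What is called first, only, known or untested is meant among the compounds shown, and "the series" means these compounds.

In an assay on isolated protein for inhibition of ubiquitin carboxyl-terminal hydrolase 7 (Homo sapiens), with stated times of 30 min and 2 h (on this read-out lower numbers stand for stronger inhibition and higher numbers for weaker inhibition), compound 1 `Cn1nc2c(=O)n(CC3(O)CCN(Cc4ccc(-c5ccncc5)cc4Cl)CC3)cnc2c1-c1ccc(CN)cc1` gives 257 nM, the highest of the three numbers in hand. Compound 2 `Cn1nc2c(=O)n(CC3(O)CCN(Cc4ccc(-c5ccco5)cc4Cl)CC3)cnc2c1-c1ccc(C2(N)CC2)cc1` gives 66.1 nM and compound 3 `Cn1nc2c(=O)n(CC3(O)CCN(Cc4ccc(-c5ccco5)cc4Cl)CC3)cnc2c1-c1ccc(C(N)=O)cc1` gives 80.8 nM; the step of a 1.2-fold higher number from compound 2 to compound 3 (0.09 log units; within the scatter) lies within the scatter. Both differ from compound 1 at two places, so their gap to compound 1 cannot be assigned to one ring alone. Compound 4 `Cn1nc2c(=O)n(CC3(O)CCN(Cc4ccc(-c5ccc[nH]5)cc4Cl)CC3)cnc2c1-c1ccc(CN)cc1` arises from compound 1 by 1H-pyrrol-2-yl in place of pyridin-4-yl on an aromatic carbon. Among the measured compounds shown here, no measured step touches this ring by itself; compounds 2 and 3 show only that two compounds carrying a five-membered aromatic ring at this place sit below compound 1. A modest decrease is therefore expected, a 1.7-fold lower number from compound 1 to compound 4 (0.23 log units; within the scatter), with wide uncertainty. Compound 4 is estimated at 150 nM, ranging from 55 nM to 400 nM.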

Compound 4, half-maximal inhibitory concentration: 193 nM
Compound 4: the middle estimate sits 1.3-fold (0.11 log units) below what was measured; the measured number falls inside the stated range.
By their numbers in this assay, from the lowest: compounds 2 and 3 (each within the scatter of the next); then compounds 4 and 1 (each within the scatter of the next).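

With the rest of compound 1 held fixed, this is the only single change shown at this ring: in this assay, 1H-pyrrol-2-yl in place of pyridin-4-yl gives a 1.3-fold lower number from compound 1 to compound 4 (0.12 log units; within the scatter) and so stays within the scatter. On this aromatic carbon, para to a large group, the read-out does not separate the six-membered ring with its hydrogen-bond acceptor from the five-membered ring with its hydrogen-bond donor. No supporting data bear on this result.

As far as these compounds go, it remains open whether the gap between compound 1 and compounds 2 and 3 belongs to this ring or to the other place where they differ. A phenyl or thiophen-2-yl group at this position also remains untested among the compounds shown.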